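The source may report more compounds than this note shows. Statements on the series, on what has been measured and on what is new or still open speak of the compounds shown alone.

Working notes on the series, read in a functional assay on SK-BR-3 cells (Homo sapiens) for antiproliferative activity (on this read-out higher numbers stand for weaker inhibition and lower numbers for stronger inhibition), throughout. Of the compounds shown here, three sharing one core have numbers so far: compound 1 (`C#CCOc1ccc(C(=O)Nc2cc3ccc(OC4CCN(C)CC4)c(C)c3oc2=O)cc1CC=C(C)C`) gives 1400 nM here, compound 2 (`Cc1c(OC2CCN(C)CC2)ccc2cc(NC(=O)c3ccc(O)c(CCC(C)C)c3)c(=O)oc12`) gives 600 nM and compound 3 (`Cc1c(OC2CCN(C)CC2)ccc2cc(NC(=O)c3ccc4c(c3)CCC(C)(C)O4)c(=O)oc12`) gives 3460 nM in the same read-out. Compound 2 holds the lowest number of the three, and its gaps to compound 1 and to compound 3 both lie beyond the scatter.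

The next compound is compound 4 (`Cc1c(OC2CCN(C)CC2)ccc2cc(NC(=O)c3ccc(O)cc3)c(=O)oc12`), which has hydrogen in place of isopentyl on an aromatic carbon of compound 2, ortho to a hydroxy group and meta to a large group (hydrogen in place of isopentyl on an aromatic carbon). For the measured compounds named here, no measured pair isolates this change. Compound 1, compound 2 and compound 3 all keep carbon substitution at that place, so the data hold no direct comparison with hydrogen there.

With compound 2 (600 nM) lowest among three compounds that all carry such substitution, a moderate step to a higher number, meaning weaker inhibition, is expected in this assay, probably beyond the scatter. The expected step is a 5.0-fold higher number from compound 2 to compound 4 (0.70 log units; beyond the scatter) on this estimate. For compound 4 the estimated value is 3000 nM in this read-out, with an expected range from 1000 nM to 10000 nM as the likely span.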

Compound 4, half-maximal inhibitory concentration: 840 nM
Compound 4: middle estimate off by 3.6-fold (0.55 log units), on the high side; measured number outside the range, below it.
By their numbers in this assay, from the lowest: compounds 2, 4 and 1 (each within the scatter of the next, the first and the last beyond it); then compound 3.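

In this assay, replacing isopentyl with hydrogen on this aromatic carbon, ortho to a hydroxy group and meta to a large group, gives a 1.4-fold higher number from compound 2 to compound 4 (0.15 log units; within the scatter). For the compounds shown here, compound 1, compound 2 and compound 3 all keep carbon substitution at this place, so this pair gives the first reading with hydrogen there, and it shows that isopentyl is not required to keep the number within the scatter of that of compound 2. Nothing measured bears on why the removal of isopentyl leaves the read-out so little moved.

On these data alone, only hydrogen and isopentyl can be compared directly at this place, so it remains open whether a shorter chain such as methyl, a longer chain, an amine or a carboxylic acid would also stay within the scatter of compound 2 or compound 4. As far as these compounds go, the part played by the hydroxy group also remains open, since compound 2 and compound 4 both keep it, while the steps from compound 1 and compound 3 to the other compounds cannot be read because each involves more than one place.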